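From Hydroxymethyl to a Hydroxypyrrolidinylmethyl Tail

A few compounds are considered here, and "the series" means these few. Any claim that something is new, unique, unknown or untested is made for them only; others in the source may bear on it.

Three compounds share one core and differ only in the group carried on an aromatic carbon: compound 1 `COc1ccc(/C=C\c2cc(OC)c(OC)c(OC)c2)cc1OCc1ccc(C=O)cc1`, compound 2 `COc1ccc(/C=C\c2cc(OC)c(OC)c(OC)c2)cc1OCc1ccc(CN2CCCC[C@@H]2C(=O)O)cc1` and compound 3 `COc1ccc(/C=C\c2cc(OC)c(OC)c(OC)c2)cc1OCc1ccc(CO)cc1`. In an ADME assay on NCM460 cells (Homo sapiens) for cytotoxicity, read by CCK-8 assay, with a stated time of 48 h (a lower number here means a stronger inhibitor, a higher number a weaker inhibitor), compound 1 gives 41000 nM. For compound 2 this assay reports only a limit, > 50000 nM. For compound 3 it likewise reports only a limit, > 50000 nM. Compound 3 therefore stands at the edge of what was measured, where (the limit of > 50000 nM in this assay, at which 2 of the 3 values shown sit). The steps of an at least 1.2-fold higher number from compound 1 to compound 2 (0.08 log units; that floor lies within the scatter) and an at least 1.2-fold higher number from compound 1 to compound 3 (0.08 log units; that floor lies within the scatter) both carry only a floor, and the step that the two limits leave unreadable from compound 2 to compound 3 cannot be read at all.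

Compound 4 `COc1ccc(/C=C\c2cc(OC)c(OC)c(OC)c2)cc1OCc1ccc(CN2CC[C@@H](O)C2)cc1` differs from compound 3 by 3-hydroxypyrrolidin-1-yl in place of hydroxy on a saturated chain carbon bound to an aromatic carbon. For the measured compounds named here, the nearest comparison is the step from compound 2 to compound 3, which swaps one ring amine for hydroxy and stays unreadable, so no measured step fixes a size or direction here. The expectation is that compound 4 remains near the limit, with a number no higher from compound 3 to compound 4 (the limit leaves the size open) expected. Compound 4 is estimated at 50000 nM, between 25000 nM and 100000 nM.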

Compound 4, half-maximal inhibitory concentration: 53000 nM
Beside the measured number, compound 4's estimate is 1.1-fold (0.03 log units) below it, within the range that was stated.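

In this assay compound 4 gives a real number, 53000 nM, so this ring amine tail on a saturated chain carbon bound to an aromatic carbon can be placed on the scale rather than only bounded. Set against the formyl group, the (3-hydroxypyrrolidin-1-yl)methyl tail gives a 1.3-fold higher number from compound 1 to compound 4 (0.11 log units; within the scatter), so these two groups cannot be told apart in this read-out. The steps to compound 4 from compound 2 and from compound 3 cannot be read, because those two compounds carry only a limit: the limit of > 50000 nM in this assay, at which 2 of the 4 values shown sit.

A plain pyrrolidin-1-yl tail, without the hydroxy, would show whether that hydroxy has any bearing on this number. On these data alone, how a morpholin-4-yl ring or a simple primary amine would read at the same place also stays open.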